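The source may report more compounds than this note shows. Statements on the series, on what has been measured and on what is new or still open speak of the compounds shown alone.

Measured in an ADME assay on microsomes from liver (Rattus norvegicus) for metabolic stability; on this read-out higher numbers stand for a longer-lived compound and lower numbers for a shorter-lived compound:
- Compound 1 `COc1cc(OCc2csc(-c3ccc(C(N)=O)cc3)n2)c2cc(-c3cn4nc(OC)sc4n3)oc2c1`: 0.4 h
- Compound 2 `COc1cc(OCc2csc(-c3ccc(C(=O)O)cc3)n2)c2cc(-c3cn4nc(OC)sc4n3)oc2c1`: > 2 h (a limit of the assay)

Compound 2 has no exact half-life in this assay. Compound 2 reads > 2 h, which is a limit and not a number.

Compound 3 `COc1cc(OCc2csc(-c3ccccc3)n2)c2cc(-c3cn4nc(OC)sc4n3)oc2c1` has hydrogen in place of carboxy on an aromatic carbon, para to a large group, so that 4-carboxyphenyl becomes phenyl: hydrogen in place of carboxy on an aromatic carbon.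

Among the compounds with values here, only one measured step bears on this change, and it concerns the same group in compound 2. With hydroxy in place of amino on a carbonyl carbon, the read-out showed an at least 5.0-fold higher number from compound 1 to compound 2 (0.69 log units; beyond the scatter). Within the data shown here, no measured step removes the whole carboxy, so this evidence is indirect. Among the measured compounds shown here, the one measured compound without the carboxy, compound 1, gives 0.4 h. A lower number in this assay, beyond the scatter, is therefore expected for compound 3. The expected step is an at least 5.7-fold lower number from compound 2 to compound 3 (0.75 log units; beyond the scatter). Compound 3 is estimated at 0.35 h, with an expected range from 0.12 h to 1.1 h.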

Compound 3, half-life: 1.22 h
For compound 3 the middle estimate is 3.5-fold (0.54 log units) below the measured one; measured number above the stated range.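

In this assay, the result separates two readings that compounds 1 and 2 alone could not: the step of a 3.1-fold higher number from compound 1 to compound 3 (0.48 log units; beyond the scatter) shows that replacing carbamoyl with plain hydrogen also gives a higher number, so carboxy is not required for a half-life above that of compound 1, whose steps to both other compounds are beyond the scatter, making it the shortest-lived of the three. Removing carboxy gives an at least 1.6-fold lower number from compound 2 to compound 3 (0.21 log units; that floor lies within the scatter), so these compounds do not establish that carboxy outperforms hydrogen at this place. The size of that step stays unresolved because compound 2 has only a limit and not a number: the limit of > 2 h in this assay, at which 1 of the 3 values shown sits.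

The compounds shown leave open how far compound 2 really lies from compound 3, and so whether the change from 4-carboxyphenyl to phenyl costs any half-life at all. They also leave open where other groups at this place would fall relative to carbamoyl and hydrogen, such as a methyl ester, a nitrile or an amine.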